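The compounds below may be only part of what the source reports. "The series", "measured", "known", "first", "only" and "open" are said of these compounds alone.

Measured in a physicochemical assay for solubility, read by HPLC, using the shake flask method, in phosphate buffer, measured as kinetic solubility, with a stated time of 20 h, at pH 6.5; a higher number here means a more soluble compound, a lower number a less soluble compound:
- compound 1 `Fc1ccc(Nc2cc3[nH]c(Nc4cc(N5CCNCC5)ccn4)nc3cn2)cc1C(F)(F)F` gives 95000 nM
- compound 2 `Fc1ccc(Nc2cc3[nH]c(Nc4ccc(N5CCN(CC6CC6)CC5)cn4)nc3cn2)cc1C(F)(F)F` gives 75000 nM
- compound 3 `CC(C)(C)N1CCN(c2ccc(Nc3nc4cnc(Nc5cccc(C(F)(F)F)c5)cc4[nH]3)nc2)CC1` gives 50000 nM

Compound 3 (50000 nM) lies within the scatter of both compound 2 and compound 1, so these three cannot be ranked. Compound 4 `FC(F)(F)c1cccc(Nc2cc3[nH]c(Nc4ccc(N5CCN(CC6CC6)CC5)cn4)nc3cn2)c1` is still unmeasured. It has cyclopropylmethyl in place of tert-butyl on an amine nitrogen in a ring. Among the measured compounds shown here, no measured pair shows this change alone. Compound 2 (75000 nM) carries the same 4-(cyclopropylmethyl)piperazin-1-yl but also differs elsewhere from compound 4. The estimated step (a 1.2-fold higher number from compound 3 to compound 4 (0.08 log units; within the scatter)) is expected to stay within the scatter in this assay. For compound 4 the expected value is 60000 nM (estimated range 28000 nM to 120000 nM).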

Compound 4, solubility: 130000 nM
The estimate for compound 4 lay 2.2-fold (0.34 log units) below the measured number; measured number above the stated range.
By their numbers in this assay, from the lowest: compounds 3, 2, 1 and 4 (each within the scatter of the next, the first and the last beyond it).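

In this assay, among the compounds shown here, cyclopropylmethyl in place of tert-butyl on the amine nitrogen in the ring gives a 2.6-fold higher number from compound 3 to compound 4 (0.41 log units; beyond the scatter), the only single change here that reaches beyond the scatter, though the step is modest. Hydrogen in place of fluoro on an aromatic carbon gives a 1.7-fold higher number from compound 2 to compound 4 (0.24 log units; within the scatter), which stays within the scatter, so this change cannot be told apart from no change. Nothing available gives a reason for either step.

From the compounds shown here alone, whether other groups on that ring nitrogen, such as a methyl or a hydroxyethyl chain, would give a step of similar size remains open.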